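The source may hold more compounds than are shown below. What is called first, only, known or untested is meant among the compounds shown, and "the series" means these compounds.

Compound 3 `Cc1ccc(-c2ccccc2OCC2=NCCN2)s1` sits at the top of the numbers recorded so far: in a functional assay for activation of Alpha-1A adrenergic receptor (Homo sapiens), read by calcium flux (on this read-out lower numbers stand for an effect already at smaller amounts and higher numbers for an effect only at larger amounts of compound), compound 3 gives 25.1 nM. Compound 1 `c1ccc(-c2ccns2)c(OCC2=NCCN2)c1` gives 5.01 nM in this assay, and compound 2 `c1ccc(-c2nccs2)c(OCC2=NCCN2)c1` gives 2.51 nM. The gap from compound 3 to each of the others is beyond the scatter, so compound 3 is the weakest of the three; the two others lie within the scatter of each other (a 2.0-fold lower number from compound 1 to compound 2 (0.30 log units; within the scatter)).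

The next compound, compound 4 `Cc1cnsc1-c1ccccc1OCC1=NCCN1`, differs from compound 3 in one place: 4-methyl-1,2-thiazol-5-yl in place of 5-methylthiophen-2-yl on an aromatic carbon.

For the measured compounds named here, two measured steps bear on it. Exchanging the 1,2-thiazol-5-yl of compound 1 for 5-methylthiophen-2-yl gave a 5.0-fold higher number from compound 1 to compound 3 (0.70 log units; beyond the scatter), and the corresponding exchange from compound 2 gave a 10-fold higher number from compound 2 to compound 3 (1.00 log units; beyond the scatter). Going by the values given here, compound 4 reverses the direction of the first of these, returning to a 1,2-thiazol-5-yl ring, but carries a methyl on it that compound 1 lacks, and no measured pair tells what that methyl does. A step toward a lower number is therefore expected, of a size close to a 5.0-fold higher number from compound 1 to compound 3 (0.70 log units; beyond the scatter) run backwards, with wider uncertainty than usual.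

For compound 4 the expected value in this assay is 7 nM, with a range from 2.5 nM to 25 nM, corresponding to an estimated step of a 3.6-fold lower number from compound 3 to compound 4 (0.55 log units; beyond the scatter).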

Compound 4, half-maximal effective concentration: 12.6 nM
For compound 4 the middle estimate is 1.8-fold (0.26 log units) below the measured one; measured number inside the range.
By their numbers in this assay, from the lowest: compounds 2 and 1 (each within the scatter of the next); then compounds 4 and 3 (each within the scatter of the next).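

In this assay, methyl in place of hydrogen on the 1,2-thiazol-5-yl ring gives the first measured read of a substituent on this ring rather than an exchange of the ring itself (a 2.5-fold higher number from compound 1 to compound 4 (0.40 log units; beyond the scatter)), and that step is beyond the scatter. Exchanging 5-methylthiophen-2-yl for 4-methyl-1,2-thiazol-5-yl, with the heavy-atom count unchanged, gives a step within the scatter (a 2.0-fold lower number from compound 3 to compound 4 (0.30 log units; within the scatter)), whereas the exchange between the rings without the 4-methyl was beyond it (a 5.0-fold higher number from compound 1 to compound 3 (0.70 log units; beyond the scatter)). The step from the 1,3-thiazol-2-yl compound is also beyond the scatter (a 5.0-fold higher number from compound 2 to compound 4 (0.70 log units; beyond the scatter)), so among these four compounds both methyl-bearing rings give higher numbers than both rings without a methyl, with no compound going against this.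

Still open, on these data alone, is whether an ethyl, methoxy or aminomethyl group on the same ring carbon would follow the methyl, and what a methyl would do on the 1,3-thiazol-2-yl ring. No independent measurement accompanies these numbers that would account for the methyl step or for the smaller gap between the methyl-bearing rings.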